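The source may hold more compounds than are shown below. What is called first, only, known or untested is meant among the compounds shown, and "the series" means these compounds.

Measured so far in a physicochemical assay for lipophilicity; on this read-out lower numbers stand for lower lipophilicity and higher numbers for higher lipophilicity:
Compound 1 `CNC(=O)c1cc(C(=O)N[C@H]2CC[C@H](O)CC2)n([C@@H](C)c2ccccc2)n1` gives 2.9
Compound 2 `CNC(=O)c1cc(C(=O)N[C@H]2CC[C@H](O)CC2)n([C@@H](C)c2cccc(C(F)(F)F)c2)n1` gives 4.1

Within the data shown here, of these two, compound 2 stands highest at 4.1 on this scale, and no other measured compound lies above it. The next compound, compound 3 `CNC(=O)c1cc(C(=O)N[C@H]2CC[C@H](O)CC2)n([C@@H](C)c2ccc(C(F)(F)F)cc2)n1`, has the same atoms as compound 2, joined differently (4-(trifluoromethyl)phenyl in place of 3-(trifluoromethyl)phenyl on a saturated chain carbon bound to an aromatic nitrogen and a saturated chain carbon). In it, 4-(trifluoromethyl)phenyl takes the place of 3-(trifluoromethyl)phenyl on the same saturated chain carbon.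

Among the measured compounds shown here, only one measured step bears on this change. Trifluoromethyl in place of hydrogen on an aromatic carbon gave a number 1.20 log units higher from compound 1 to compound 2 (beyond the scatter) as a large step, beyond the scatter. That step compares a compound without the group to one with it, whereas compound 3 keeps the group and only carries it elsewhere on the aromatic ring. For the measured compounds named here, no measured pair compares the two placements, so the large step offers no direct guide to their difference. No shift in either direction is therefore expected in this assay beyond the scatter. The expected step is no change at the digits printed from compound 2 to compound 3 (within the scatter) and is estimated to lie within the scatter. For compound 3 the estimated value is 4.1 with an expected range from 3.7 to 4.5 in this measurement.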

Compound 3, distribution coefficient: 3.9
Compound 3: middle estimate off by 0.20 log units, on the high side; the measured number falls inside the stated range.
By their numbers in this assay, from the lowest: compound 1; then compounds 3 and 2 (each within the scatter of the next).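

In this assay, carrying the trifluoromethyl group to the other ring placement gives a number 0.20 log units lower from compound 2 to compound 3 (within the scatter), so on this read-out the 3-(trifluoromethyl)phenyl and 4-(trifluoromethyl)phenyl groups cannot be told apart on this saturated chain carbon. Until now, the effect of adding trifluoromethyl rested on a single pair, but the second placement gives a number 1.00 log units higher from compound 1 to compound 3 (beyond the scatter), which shows that the rise beyond the scatter is not confined to one placement: both compound 2 and compound 3 stand clear of the unsubstituted compound 1, and neither goes against this within these three compounds. Nothing measured here accounts for the close agreement between the two placements or for the rise itself.

The compounds shown leave open whether this insensitivity to placement belongs to trifluoromethyl alone or would also hold for a different group on the aromatic ring, such as a methoxy group, a nitrile or a carboxylic acid. They also leave open how such a group would compare with hydrogen and with trifluoromethyl on the same saturated chain carbon in this assay, since every substituted compound here carries trifluoromethyl.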